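The source may report more compounds than this note shows. Statements on the series, on what has been measured and on what is new or still open speak of the compounds shown alone.

Compound 1 `Cc1nc(-c2ccc(C(F)(F)F)cc2)sc1CNc1ccc(CC(=O)O)cc1` is the weakest of the three measured compounds in a functional assay on CHO cells for agonist activity at Free fatty acid receptor 1 (Homo sapiens), read by a luciferase reporter (a higher number here means a larger maximal response, a lower number a smaller maximal response), where compound 1 reaches 18%. The other two compounds share a different core: compound 2 `CNC(=O)CCc1ccc(NCc2cccc(Oc3ccccc3)c2)cc1` gives 67% in this assay, and compound 3 `CN(C)C(=O)CCc1ccc(NCc2cccc(Oc3ccccc3)c2)cc1` gives 50%. Within the data shown here, the only measured step, a number 17 percentage points lower from compound 2 to compound 3 (beyond the scatter), involves methyl in place of hydrogen on an amide-type nitrogen and lies on that other core, so it does not speak directly to the change under consideration.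

Compound 4 `Cc1nc(-c2ccc(C(F)(F)F)cc2)sc1CNc1ccc([C@H]2C[C@@H]2C(=O)NO)cc1` keeps the core of compound 1 and differs by 2-(hydroxycarbamoyl)cyclopropyl in place of carboxymethyl on an aromatic carbon. Among the measured compounds shown here, no measured pair shows what this exchange does in this assay, so the expectation rests on compound 1 alone. For the measured compounds named here, with a low starting point of 18% for compound 1 and no precedent for the new group, the expected step of a number 2 percentage points higher from compound 1 to compound 4 (within the scatter) is small and the direction uncertain. Compound 4 is therefore estimated at 20%, with a plausible range from 5% to 45% in this assay.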

Compound 4, largest response reached (reported as percent of maximum), in percent of the reference or control that the assay uses: 78%
Beside the measured number, compound 4's estimate is 58 percentage points below it, outside the stated range (above it).
By their numbers in this assay, from the lowest: compound 1; then compound 3; then compound 2; then compound 4.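

On the core of compound 1, exchanging carboxymethyl for 2-(hydroxycarbamoyl)cyclopropyl on the aromatic carbon para to a large group gives a number 60 percentage points higher from compound 1 to compound 4 (beyond the scatter). This shows that the maximal response in this assay is highly sensitive to the group at this position, and that the core can give a large response without the carboxylic acid of compound 1. No measurement shown here explains this rise.

As far as these compounds go, the exchange adds the three-membered ring and replaces the carboxylic acid with the hydroxycarbamoyl group in a single step, so the contribution of each remains unknown. From the compounds shown here alone, on the same core, a 2-carboxycyclopropyl group would test the ring alone and a hydroxycarbamoylmethyl group the end group alone, while the effect of the opposite arrangement at the two stereocentres also remains open.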